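A few compounds are considered here, and "the series" means these few. Any claim that something is new, unique, unknown or untested is made for them only; others in the source may bear on it.

For the measured compounds named here, in an ADME assay on microsomes from liver (Homo sapiens) for metabolic stability, with a stated time of 10 min (on this read-out higher numbers stand for a more stable compound and lower numbers for a less stable compound), compound 2 (`O=C(O)[C@H]1CC[C@H](C(=O)N2CC[C@](c3ccc(C(OCc4c(F)cccc4Cl)(C(F)(F)F)C(F)(F)F)cc3)(S(=O)(=O)c3ccc(F)cc3)C2)CC1`) gives 100%, the higher of the two numbers so far, while compound 1 (`Cc1cccc(F)c1COC(c1ccc([C@]2(S(=O)(=O)c3ccc(F)cc3)CCN(C(=O)[C@H]3CC[C@H](C(=O)O)CC3)C2)cc1)(C(F)(F)F)C(F)(F)F`) gives 79%. Compound 3 (`O=C(O)[C@H]1CC[C@H](C(=O)N2CC[C@](c3ccc(C(OCC4CC4)(C(F)(F)F)C(F)(F)F)cc3)(S(=O)(=O)c3ccc(F)cc3)C2)CC1`) differs from compound 2 as follows: cyclopropyl in place of 2-chloro-6-fluorophenyl on a saturated chain carbon bound to an oxygen on a saturated carbon. This places cyclopropyl where 2-chloro-6-fluorophenyl stood. Going by the values given here, only one measured step bears on this, and only loosely: a number 21 percentage points higher from compound 1 to compound 2 (beyond the scatter). That modest step does not show what removing the whole aromatic group would do. A modest fall is therefore expected, estimated as a number 15 percentage points lower from compound 2 to compound 3 (beyond the scatter). For compound 3 the estimated value is 85%, with an expected range from 65% to 100%.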

Compound 3, percent of the compound remaining: 75%
For compound 3 the middle estimate is 10 percentage points above the measured one; the measured number falls inside the stated range.
By their numbers in this assay, from the lowest: compounds 3 and 1 (each within the scatter of the next); then compound 2.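

In this assay, cyclopropyl at this place gives a number 25 percentage points lower from compound 2 to compound 3 (beyond the scatter) and so does not hold the number reached with 2-chloro-6-fluorophenyl. The same replacement gives a number 4 percentage points lower from compound 1 to compound 3 (within the scatter) when it is made on 2-fluoro-6-methylphenyl, so what it does depends on which aromatic group leaves. Nothing measured here explains either step. On these data alone, whether an unsubstituted phenyl or a longer chain such as n-butyl at this place would stay close to compound 2 or to compound 3 remains open.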